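The source may hold more compounds than are shown below. What is called first, only, known or untested is meant among the compounds shown, and "the series" means these compounds.

In a functional assay on DU-145 cells (Homo sapiens) for inhibition, read by trypan blue exclusion, with a stated time of 96 h (on this read-out lower numbers stand for stronger inhibition of growth and higher numbers for weaker inhibition of growth), compound 1 `COc1ccccc1/C=C(/SCc1ccc(F)cc1)C(=O)c1ccc(Br)cc1` gives 10000 nM. Compound 3 `CN(C)c1ccc(/C=C(/SCc2ccc(F)cc2)C(=O)c2ccc(Br)cc2)cc1` gives 50000 nM, the higher of the two actual numbers in this small set, which makes it the weaker growth inhibitor of that pair. Compound 2 `O=C(O)c1ccc(C(=O)/C(=C\c2ccc(Br)cc2)SCc2ccc(F)cc2)cc1` gives > 100000 nM, which is a limit of the assay and not a number.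

Compound 4 `O=C(/C(=C\c1ccc(Br)cc1)SCc1ccc(F)cc1)c1ccc(Br)cc1` has bromo in place of dimethylamino on an aromatic carbon, so 4-(dimethylamino)phenyl becomes 4-bromophenyl: bromo in place of dimethylamino on an aromatic carbon.

Among the compounds with values here, only one measured step involves the group that leaves here. It is a 5.0-fold higher number from compound 1 to compound 3 (0.70 log units; beyond the scatter), a modest step that arrives at 4-(dimethylamino)phenyl from 2-methoxyphenyl and moves to weaker inhibition. Within the data shown here, compound 2 also carries 4-bromophenyl, but it differs from compound 4 elsewhere, so it gives no direct step for this change. The evidence is therefore thin. Leaving 4-(dimethylamino)phenyl is expected to give a modest move toward a lower number in this assay, of about the same size as that single step and with wide uncertainty. The expected change is a 3.3-fold lower number from compound 3 to compound 4 (0.52 log units; beyond the scatter). For compound 4 the estimated value is 15000 nM, with an expected range from 3000 nM to 70000 nM.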

Compound 4, concentration for 50% growth inhibition: 25000 nM
Beside the measured number, compound 4's estimate is 1.7-fold (0.22 log units) below it; measured number inside the range.
By their numbers in this assay, from the lowest: compound 1; then compounds 4 and 3 (each within the scatter of the next). At a limit, above all of these: compound 2.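

In this assay, within the data shown here, putting bromo in place of dimethylamino on this aromatic carbon, para to a large group, gives a 2.0-fold lower number from compound 3 to compound 4 (0.30 log units; within the scatter), so this single change does not separate the two compounds, and a second group at this carbon now adds to the one reading that compound 3 gave. Compound 4 also sits apart from the 2-methoxyphenyl compound, with a 2.5-fold higher number from compound 1 to compound 4 (0.40 log units; beyond the scatter), so both groups on the 4-substituted phenyl now give higher numbers than compound 1, although that comparison changes where the substituent sits as well as what it is. Compound 2 carries a carboxy group where compound 4 has a second bromo, on the other aromatic ring, and its reading is a limit and not a number, so an at least 4.0-fold lower number from compound 2 to compound 4 (0.60 log units; beyond the scatter) gives only a lower bound on the size of that step: the limit of > 100000 nM in this assay, at which 1 of the 4 values shown sits.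

Still open, from the compounds shown here alone, is whether the lower number of compound 1 follows from the methoxy group itself or from where it sits, which 4-methoxyphenyl at this carbon could help to settle. Also open, going by these compounds, is how a primary amine or a hydroxyl group at this same carbon would read, set against dimethylamino and bromo.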